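Working notes: from compound 3 to compound 4

The compounds below may be only part of what the source reports. "The series", "measured", "known", "first", "only" and "open" are said of these compounds alone.

Measured in a functional assay on MDA-MB-231 cells (Homo sapiens) for cytotoxicity, read by MTT assay, with a stated time of 72 h; a higher number here means a weaker inhibitor, a lower number a stronger inhibitor:
- compound 1 `CN(C)CCCCCn1c2c(c3ccccc31)C(=O)c1c[n+]([O-])c3ccccc3c1C2=O`: 240 nM
- compound 2 `CC1(C)OCC(Cn2cc(Cn3c4c(c5ccccc53)C(=O)c3c[n+]([O-])c5ccccc5c3C4=O)nn2)O1`: 230 nM
- compound 3 `CN1CCN(CCCCCCn2c3c(c4ccccc42)C(=O)c2c[n+]([O-])c4ccccc4c2C3=O)CC1`: 2400 nM

Compound 3 has the highest number of the three, and the other two values lie within the scatter of each other. The next compound to be read is compound 4 `O=C1c2c[n+]([O-])c3ccccc3c2C(=O)c2c1c1ccccc1n2Cc1cn(C[C@@H](O)CO)nn1`. The change is 1-(2,3-dihydroxypropyl)-1H-1,2,3-triazol-4-yl in place of 5-(4-methylpiperazin-1-yl)pentyl on a saturated chain carbon bound to an aromatic nitrogen, on a saturated chain carbon bound to an aromatic nitrogen.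

For the measured compounds named here, only one measured step bears directly on the leaving side: a 10-fold higher number from compound 1 to compound 3 (1.00 log units; beyond the scatter). That step alters the amine end of the chain only, so it does not cover the full exchange. On the entering side, compound 2 also carries a 1,2,3-triazole and gives 230 nM in this assay. Going by the values given here, its diol differs from that of compound 4, and no measured compound holds the free 2,3-dihydroxypropyl group, so the read-across is loose. With three compounds, no firm pattern can be claimed.

A lower number is therefore expected, though probably not quite as low as that of compound 2. The expected change is a 6.0-fold lower number from compound 3 to compound 4 (0.78 log units; beyond the scatter). For compound 4 the estimated value is 400 nM, with an expected range of 120 nM to 1300 nM.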

Compound 4, half-maximal inhibitory concentration: 670 nM
For compound 4 the middle estimate is 1.7-fold (0.22 log units) below the measured one, and the stated range covers the measured number.
By their numbers in this assay, from the lowest: compounds 2 and 1 (each within the scatter of the next); then compound 4; then compound 3.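

In this assay the exchange gives a 3.6-fold lower number from compound 3 to compound 4 (0.55 log units; beyond the scatter) and shows that, on a saturated chain carbon bound to an aromatic nitrogen, 1-(2,3-dihydroxypropyl)-1H-1,2,3-triazol-4-yl with no amine at its end is compatible with a number well under that of the 5-(4-methylpiperazin-1-yl)pentyl chain. The two triazoles now give the first reading within that subseries: the read is a 2.9-fold higher number from compound 2 to compound 4 (0.46 log units; beyond the scatter) for 1,2-dihydroxyethyl in place of 2,2-dimethyl-1,3-dioxolan-4-yl, so the triazole alone does not fix the number and the group at its far end still counts. Against the shorter amine the read is a 2.8-fold higher number from compound 1 to compound 4 (0.45 log units; beyond the scatter) for 1-(2,3-dihydroxypropyl)-1H-1,2,3-triazol-4-yl in place of 4-(dimethylamino)butyl, so the triazole diol recovers only part of what the piperazine chain gives up.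

Still open, as far as these compounds go, is how a triazole ending in a dimethylamino group, a single hydroxyl, a methyl ether or a carboxylic acid would read here, and whether the opposite configuration at the stereocentre of the diol moves the number. No measurement beyond these cell values bears on the reason for any of these steps.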